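Dipropyl to dibutyl on the carbamate of compound 3

The compounds below may be only part of what the source reports. "The series", "measured", "known", "first", "only" and "open" are said of these compounds alone.

Compound 1, `COc1cc(C(=O)N2CCN(C(=O)c3cc(OC)c(OC)c(OC)c3)C(COC(=O)C3CCCCC3)C2)cc(OC)c1OC`, gives 290 nM in a functional assay (Oryctolagus cuniculus) for inhibition of platelet-activating factor receptor (Cavia porcellus); a lower number here means a stronger inhibitor, a higher number a weaker inhibitor.
Compound 2, `CCC(C)CNC(=O)OCC1CN(C(=O)c2cc(OC)c(OC)c(OC)c2)CCN1C(=O)c1cc(OC)c(OC)c(OC)c1`, gives 470 nM in this assay.
Compound 3, `CCCN(CCC)C(=O)OCC1CN(C(=O)c2cc(OC)c(OC)c(OC)c2)CCN1C(=O)c1cc(OC)c(OC)c(OC)c1`, gives 380 nM in this assay.

Compound 3 stands second highest of the three numbers. Its nearest neighbour is compound 2, reached by a 1.2-fold lower number from compound 2 to compound 3 (0.09 log units; within the scatter); the furthest is compound 1, with a 1.3-fold higher number from compound 1 to compound 3 (0.12 log units; within the scatter). Both steps lie within the scatter, and the third step, a 1.6-fold higher number from compound 1 to compound 2 (0.21 log units; within the scatter), lies there as well, so the three measured compounds are not separated from one another by these data.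

Compound 4, `CCCCN(CCCC)C(=O)OCC1CN(C(=O)c2cc(OC)c(OC)c(OC)c2)CCN1C(=O)c1cc(OC)c(OC)c(OC)c1`, has not yet been measured in this assay. It differs from compound 3 in one place: dibutylamino in place of dipropylamino on a carbonyl carbon. Going by the values given here, the steps that bear on this change are those that exchange one group on the same carbonyl carbon: the exchange of cyclohexyl for (2-methylbutyl)amino, of cyclohexyl for dipropylamino, and of (2-methylbutyl)amino for dipropylamino, none of which moved the number beyond the scatter. The change from dipropylamino to dibutylamino is smaller than any of these, so no step beyond the scatter is expected in either direction. Compound 4 is therefore expected to give 380 nM, within a range of 190 nM to 760 nM, which corresponds to an expected step of no change at the digits printed from compound 3 to compound 4 (within the scatter).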

Compound 4, half-maximal inhibitory concentration: 1250 nM
For compound 4 the middle estimate is 3.3-fold (0.52 log units) below the measured one, outside the stated range (above it).
By their numbers in this assay, from the lowest: compounds 1, 3 and 2 (each within the scatter of the next); then compound 4.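

In this assay, going by these compounds alone, cyclohexyl, (2-methylbutyl)amino and dipropylamino on this carbonyl carbon could not be separated from one another, but dibutylamino gives a 3.3-fold higher number from compound 3 to compound 4 (0.52 log units; beyond the scatter) and so brings the first step beyond the scatter at this position. The other two comparisons agree, with a 2.7-fold higher number from compound 2 to compound 4 (0.42 log units; beyond the scatter) and a 4.3-fold higher number from compound 1 to compound 4 (0.63 log units; beyond the scatter), which makes compound 4 the weakest inhibitor of the four and shows that the position does respond to the group placed there, even though the exchange only takes the group from 7 to 9 heavy atoms and leaves the counted donors and acceptors unchanged. Nothing available here accounts for this rise in the number.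

The compounds shown leave open whether the number keeps rising with a longer chain such as dipentylamino or whether dibutylamino marks a single sharp edge at this position. They also leave open whether one butyl chain alone, as in butylamino, would behave like the pair in compound 4, or whether a chain ending in an amine or a carboxylic acid would give a different number.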